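The source may report more compounds than this note shows. Statements on the series, on what has been measured and on what is new or still open speak of the compounds shown alone.

Compound 3 `Clc1ccccc1-c1nnc2nnc(N3CCCC3)nn12` gives 2990 nM in a functional assay on BeWo cells (Homo sapiens) for cytotoxicity, read by MTT assay, with a stated time of 72 h (a lower number here means a stronger inhibitor, a higher number a weaker inhibitor), the lowest of the three numbers measured. Compound 1 `Cc1nnc2nnc(N3CCCC3)nn12` gives 5360 nM in this assay, and compound 2 `CCCCCc1nnc2nnc(N3CCCC3)nn12` gives 27900 nM. The step of a 1.8-fold lower number from compound 1 to compound 3 (0.25 log units; within the scatter) stays within the scatter, whereas a 9.3-fold lower number from compound 2 to compound 3 (0.97 log units; beyond the scatter) lies beyond it. Compound 4 `CC(C)c1nnc2nnc(N3CCCC3)nn12` differs from compound 3 by isopropyl in place of 2-chlorophenyl on an aromatic carbon. Isopropyl is a short chain, nearer methyl than pentyl, and the step of a 5.2-fold higher number from compound 1 to compound 2 (0.72 log units; beyond the scatter) indicates that a longer chain at this position raises the number. Compound 4 is therefore expected to show a modest rise in this assay, a 2.2-fold higher number from compound 3 to compound 4 (0.34 log units; beyond the scatter). The estimate for compound 4 is 6500 nM, with an expected range from 2500 nM to 17000 nM.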

Compound 4, half-maximal inhibitory concentration: 3430 nM
The estimate for compound 4 lay 1.9-fold (0.28 log units) above the measured number; low and high end bracket the measured number.
By their numbers in this assay, from the lowest: compounds 3, 4 and 1 (each within the scatter of the next); then compound 2.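

In this assay, the ring of 2-chlorophenyl proves unnecessary at this position: isopropyl, with no ring, cannot be told apart from it, with a 1.1-fold higher number from compound 3 to compound 4 (0.06 log units; within the scatter), nor from methyl, with a 1.6-fold lower number from compound 1 to compound 4 (0.19 log units; within the scatter). Pentyl alone stands apart from these groups, and the change to isopropyl gives an 8.1-fold lower number from compound 2 to compound 4 (0.91 log units; beyond the scatter), so the earlier rise with chain length does not extend to every group larger than methyl. No measurement here accounts for this. From the compounds shown here alone, how long a chain must be before the number rises stays open, as does the outcome with an amine or a carboxylic acid on this aromatic carbon.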